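Removing the Nitro Group from Compound 2

The source may hold more compounds than are shown below. What is called first, only, known or untested is meant among the compounds shown, and "the series" means these compounds.

Within the data shown here, in a toxicity assay on HepG2 cells (Homo sapiens) for cytotoxicity, read by MTT assay, with a stated time of 72 h (a higher number here means that more compound is tolerated, a lower number that less compound is tolerated), compound 2 `O=[N+]([O-])c1ccc2nc(Nc3ccc(Br)cc3)c(Nc3ccc(Br)cc3)nc2c1` gives 3970 nM, one of only two numbers obtained. The other comes from compound 3 `O=[N+]([O-])c1ccc2nc(NCc3ccccc3)c(NCc3ccccc3)nc2c1`, which gives 5080 nM, and the two lie within the scatter of each other, so neither can be called better tolerated. For compound 1 `Clc1ccc(Nc2nc3ccc(N4CCCC4)cc3nc2Nc2ccc(Cl)c(Cl)c2)cc1Cl` the entry in this assay is "nd" (no result reported), no result having been reported. Compound 4 `Brc1ccc(Nc2nc3ccccc3nc2Nc2ccc(Br)cc2)cc1` differs from compound 2 by a single change: hydrogen in place of nitro on an aromatic carbon. Among the measured compounds shown here, no step between measured compounds shows what this change does here, so the expectation rests on compound 2 alone. The step of a 1.1-fold higher number from compound 2 to compound 4 (0.05 log units; within the scatter) is expected to be small, with no direction beyond the scatter. Compound 4 is therefore estimated at 4500 nM in this assay, within a range from 1500 nM to 14000 nM.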

Compound 4, half-maximal cytotoxic concentration: 4640 nM
Beside the measured number, compound 4's estimate is 1.0-fold (0.01 log units) below it; the range from low to high includes it.
By their numbers in this assay, from the lowest: compounds 2, 4 and 3 (each within the scatter of the next).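

In this assay, among these compounds, hydrogen in place of nitro on an aromatic carbon gives a 1.2-fold higher number from compound 2 to compound 4 (0.07 log units; within the scatter), the first step that can be read at this position. For this pair, the nitro group can therefore leave the shared core without a difference that stands clear of the scatter. No measured finding accounts for this result.

As far as these compounds go, whether an amine, a carboxylic acid or a methoxy group at the same carbon would also stay within the scatter of compound 2 remains open. So does whether the same change would give a similar step on compound 3.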